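The source may hold more compounds than are shown below. What is called first, only, known or untested is meant among the compounds shown, and "the series" means these compounds.

Measured so far in an assay for inhibition of HSP60/HSP10 (Homo sapiens), with a stated time of 60 min; on this read-out higher numbers stand for weaker inhibition and lower numbers for stronger inhibition:
Compound 1, `O=C(Nc1cccc(Cl)c1)c1ccccc1O`, a limit of > 100000 nM.
Compound 2, `COc1ccccc1C(=O)Nc1cccc(Cl)c1`, a limit of > 100000 nM.
Compound 3, `COc1ccccc1C(=O)Nc1ccccc1`, a limit of > 100000 nM.

Compound 2 stands only as a limit in this assay, as do its two neighbours, all three resting at the limit of > 100000 nM in this assay, at which 3 of the 3 values shown sit. Compound 4, `COc1ccc(Br)cc1C(=O)Nc1cccc(Cl)c1`, differs from compound 2 by bromo in place of hydrogen on an aromatic carbon. The measured steps that touch compound 2 were a step that the two limits leave unreadable from compound 1 to compound 2 and a step that the two limits leave unreadable from compound 2 to compound 3; neither could be read, so no size is known for any change around this core. With every value sitting at the limit, compound 4 is expected to give 150000 nM, between 30000 nM and 1000000 nM. The step is expected to be a step that the limit leaves unreadable from compound 2 to compound 4, and most likely only a limit will again be recorded.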

Compound 4, half-maximal inhibitory concentration: > 100000 nM
Compound 4 gave a limit, no number; the forecaster's own chance of this, stated with the estimate: 80%; the middle value does not contradict the limit.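

Compound 2 and compound 4 both stand only as limits, so the step between them cannot be read: the limit of > 100000 nM in this assay, at which 4 of the 4 values shown sit. The compounds shown leave open whether any change to the shared core would give a number rather than a limit in this assay.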